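Pyrrolidine amide after the triazole: cytotoxicity notes

The source may hold more compounds than are shown below. What is called first, only, known or untested is meant among the compounds shown, and "the series" means these compounds.

Measured in an ADME assay on HeLa cells (Homo sapiens) for cytotoxicity, read by MTT assay; on this read-out lower numbers stand for stronger inhibition and higher numbers for weaker inhibition:
- Compound 1 `COc1ccc(C[C@H]2COC(=O)[C@@H]2Cc2ccc(OCC(=O)Nc3ccc(C)cc3)c(OC)c2)cc1OC`: 228000 nM
- Compound 2 `COc1ccc(C[C@H]2COC(=O)[C@@H]2Cc2ccc(OCc3cn(-c4ccc(C)cc4)nn3)c(OC)c2)cc1OC`: >= 600000 nM (a limit of the assay)

Compound 2 stands at the limit of >= 600000 nM in this assay, at which 1 of the 2 values shown sits, so its entry is a limit and not a number. The next structure is compound 3 `COc1ccc(C[C@H]2COC(=O)[C@@H]2Cc2ccc(OCC(=O)N3CCCC3)c(OC)c2)cc1OC`, with the change ((pyrrolidin-1-yl)carbonyl in place of 1-(4-methylphenyl)-1H-1,2,3-triazol-4-yl on a saturated chain carbon bound to an oxygen on an aromatic ring). This places (pyrrolidin-1-yl)carbonyl where compound 2 has 1-(4-methylphenyl)-1H-1,2,3-triazol-4-yl.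

Among the measured compounds shown here, only one measured step bears on this change: an at least 2.6-fold higher number from compound 1 to compound 2 (0.42 log units; beyond the scatter). That step lies beyond the scatter and involves the same saturated chain carbon. Compound 3 again has a carbonyl there, as compound 1 does, but it has no 4-methylphenyl group. A move back towards the number of compound 1 is therefore expected, meaning a lower number than the limit of compound 2. Its size is poorly defined, and compound 3 may also reach the limit.

The expected change is an at least 1.7-fold lower number from compound 2 to compound 3 (0.23 log units; that floor lies within the scatter). The estimate for compound 3 is 350000 nM, with an expected range of 150000 nM to 600000 nM.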

Compound 3, half-maximal inhibitory concentration: >= 600000 nM
Compound 3: only a limit was reported; the forecaster's own chance of this, stated with the estimate: 35%; middle value at least 1.7-fold (0.23 log units) away from the limit.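

In this assay compound 3 gives >= 600000 nM, which is a limit and not a number. Placing pyrrolidin-1-yl in place of (4-methylphenyl)amino on the carbonyl carbon gives an at least 2.6-fold higher number from compound 1 to compound 3 (0.42 log units; beyond the scatter), so at this position the carbonyl alone does not restore a measurable number, and the group on the carbonyl carbon also counts. Compound 1 is now the only compound of the three with a number, and the step from compound 2 to compound 3 cannot be read, as both entries sit at the same limit: the limit of >= 600000 nM in this assay, at which 2 of the 3 values shown sit.

On these data alone, it remains open which part of the (4-methylphenyl)amino group goes with the number of compound 1, the amide hydrogen or the 4-methylphenyl ring, and a phenylamino or benzylamino group on the same carbonyl carbon would separate these parts. Any ordering of compound 2 and compound 3 also remains open, as does whether other groups on this saturated chain carbon would give a number at all.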